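A few compounds are considered here, and "the series" means these few. Any claim that something is new, unique, unknown or untested is made for them only; others in the source may bear on it.

In an assay on isolated protein for inhibition of LIM domain kinase 1 (Homo sapiens), read by Kinase-Glo, with a stated time of 60 min (on this read-out lower numbers stand for stronger inhibition and higher numbers for weaker inhibition), compound 1, `Nc1c(C(=O)O)sc2ncccc12`, gives > 100000 nM, which is a limit of the assay rather than a number. Compound 2, `CCOC(=O)c1sc2ccccc2c1N`, likewise gives > 100000 nM in this assay, again a limit. Going by the values given here, compound 3, `Cc1ccnc2sc(C(N)=O)c(N)c12`, gives 11000 nM in this assay, the one measured number among the three. Among the compounds with values here, compound 1 therefore sits at the limit described by the limit of > 100000 nM in this assay, at which 2 of the 3 values shown sit, with compound 3 the only compound showing measurable inhibition. Compound 4, `CNC(=O)c1sc2ncccc2c1N`, differs from compound 1 by methylamino in place of hydroxy on a carbonyl carbon. Within the data shown here, no step between two measured compounds is available, but the carboxamide of compound 3 is the one group here paired with a number, so a drop toward stronger inhibition is expected, of about an at least 5.0-fold lower number from compound 1 to compound 4 (0.69 log units; beyond the scatter). Compound 4 is estimated at 20000 nM, with a range from 3000 nM to 100000 nM.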

Compound 4, half-maximal inhibitory concentration: > 100000 nM
Compound 4: no number, only a limit; the forecaster's own chance of this, stated with the estimate: 25%; at least 5.0-fold (0.69 log units) between middle value and limit.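

No step can be read from compound 1 to compound 4, since each gives only a limit and not a number: the limit of > 100000 nM in this assay, at which 3 of the 4 values shown sit.

The compounds shown leave open whether methylamino in place of hydroxy on a carbonyl carbon changes inhibition at all in this assay.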